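The compounds below may be only part of what the source reports. "The series", "measured", "known", "first", "only" and "open" are said of these compounds alone.

Measured so far:
compound 1 `CSc1nc(NCCCCNc2ccnc3cc(Cl)ccc23)c(C#N)c(-c2cccc([N+](=O)[O-])c2)n1` with 100000 nM
compound 2 `COc1cc(-c2nc(SC)nc(NCCCCNc3ccnc4cc(Cl)ccc34)c2C#N)cc(OC)c1OC` with 20000 nM

Within the data shown here, in an ADME assay on HeLa cells (Homo sapiens) for cytotoxicity, read by microscopy (on this read-out higher numbers stand for lower toxicity in this test and lower numbers for higher toxicity in this test), compound 2 gives the lower of the two numbers, and the only step in this set, a 5.0-fold lower number from compound 1 to compound 2 (0.70 log units; beyond the scatter), separates it from compound 1. Compound 3 `CSc1nc(NCCCCNc2ccnc3cc(Cl)ccc23)c(C#N)c(-c2ccc(C)cc2)n1` is the next compound to be tested. Its change from compound 2 is 4-methylphenyl in place of 3,4,5-trimethoxyphenyl on an aromatic carbon. Among the measured compounds shown here, no measured step involves a 4-methylphenyl group, so the only guide is the step from compound 1 to compound 2, which shows that exchanging the aryl group at this position moves the number by a modest amount in this assay. An exchange of similar scope is therefore expected to shift the number by no more than a modest step, with the direction uncertain; compound 3 is estimated at 40000 nM, between 10000 nM and 150000 nM, which corresponds to an expected step of a 2.0-fold higher number from compound 2 to compound 3 (0.30 log units; within the scatter).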

Compound 3, minimum cytotoxic concentration: 100000 nM
Compound 3: middle estimate off by 2.5-fold (0.40 log units), on the low side; the range from low to high includes it.
By their numbers in this assay, from the lowest: compound 2; then compounds 1 and 3 (each within the scatter of the next).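

In this assay, 4-methylphenyl in place of 3,4,5-trimethoxyphenyl on this aromatic carbon gives a 5.0-fold higher number from compound 2 to compound 3 (0.70 log units; beyond the scatter), while the exchange of 3-nitrophenyl for 4-methylphenyl gives no change at the digits printed from compound 1 to compound 3 (within the scatter). Among these three compounds, then, the change in the aryl group at this position matters only when 3,4,5-trimethoxyphenyl is involved: the 3-nitrophenyl and 4-methylphenyl groups read alike despite their different substituents, and compound 2 alone stands apart. Nothing measured here bears on why this group differs from the other two.

The compounds shown leave open whether all the methoxy groups of 3,4,5-trimethoxyphenyl are needed for the lower number, or whether a single 4-methoxyphenyl group would give it too. They also leave open how an unsubstituted phenyl group or an aryl group carrying an amine would read at this position.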